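Fluorine on the Central Ring: Expecting Compound 4

The source may hold more compounds than are shown below. What is called first, only, known or untested is meant among the compounds shown, and "the series" means these compounds.

compound 1 `Cn1ccc2c(Oc3ccc(NC(=O)c4cc5cccnc5n(-c5ccc(F)cc5)c4=O)cc3)ccnc21`: 250 nM
compound 2 `Cn1ccc2c(Oc3ccc(NC(=O)c4cc5cccnc5n(-c5ccc(Br)cc5)c4=O)cc3)ccnc21`: 690 nM
compound 3 `Cn1ccc2c(Oc3ccc(NC(=O)c4cc5cccnc5n(-c5ccc(F)c(Cl)c5)c4=O)cc3)ccnc21`: 1210 nM

In a functional assay on HT-29 cells (Homo sapiens) for antiproliferative activity, read by MTT assay, with a stated time of 72 h (on this read-out lower numbers stand for stronger inhibition and higher numbers for weaker inhibition), compound 1 gives the lowest number of the three. The steps of a 2.8-fold higher number from compound 1 to compound 2 (0.44 log units; beyond the scatter) and a 4.8-fold higher number from compound 1 to compound 3 (0.68 log units; beyond the scatter) both raise the number, while a 1.8-fold higher number from compound 2 to compound 3 (0.24 log units; within the scatter) stays within the scatter. Compound 4 `Cn1ccc2c(Oc3ccc(NC(=O)c4cc5cccnc5n(-c5ccc(F)cc5)c4=O)cc3F)ccnc21` differs from compound 1 by fluoro in place of hydrogen on an aromatic carbon, ortho to a large group and meta to a large group. For the measured compounds named here, none of the measured steps touches this ring, so no direct comparison exists; the nearest case, a halogen added elsewhere in a 4.8-fold higher number from compound 1 to compound 3 (0.68 log units; beyond the scatter), gave a modest weakening. A step of at most that size, possibly none beyond the scatter, is therefore expected in this assay. The estimate for compound 4 is 320 nM, range 130 nM to 800 nM. This expected step is a 1.3-fold higher number from compound 1 to compound 4 (0.11 log units; within the scatter).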

Compound 4, half-maximal inhibitory concentration: 160 nM
Beside the measured number, compound 4's estimate is 2.0-fold (0.30 log units) above it; low and high end bracket the measured number.
By their numbers in this assay, from the lowest: compounds 4 and 1 (each within the scatter of the next); then compounds 2 and 3 (each within the scatter of the next).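

Compound 4 is the first compound shown with a change on this ring: fluoro in place of hydrogen on an aromatic carbon, ortho to a large group and meta to a large group, gives a 1.6-fold lower number from compound 1 to compound 4 (0.19 log units; within the scatter) in this assay. The two compounds therefore cannot be told apart, so a single fluorine is tolerated at this position. Nothing available explains this result.

From the compounds shown here alone, whether a larger group here, such as chloro, methoxy or an amine, would also be tolerated remains open.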